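Three aryl substituents on one shared core, and a fourth

The source may hold more compounds than are shown below. What is called first, only, known or untested is meant among the compounds shown, and "the series" means these compounds.

Compound 1 `c1ccc(-c2cn3ccnc3c(-c3ccc4ncn(C5CCCCC5)c4c3)n2)cc1`: 27.8%
Compound 2 `Fc1ccc(-c2cn3ccnc3c(-c3ccc4ncn(C5CCCCC5)c4c3)n2)cc1`: 17.3%
Compound 3 `CC(=O)c1ccc(-c2cn3ccnc3c(-c3ccc4ncn(C5CCCCC5)c4c3)n2)cc1`: 2.82%

All three numbers come from a functional assay on SF-539 cells (Homo sapiens) for inhibition, read by sulforhodamine B assay, with a stated time of 48 h, tested at 10 uM; a higher number here means more inhibition at the concentration tested (going by the name of the read-out), a lower number less inhibition. Compound 3 stands lowest of the three: a number 25 percentage points lower from compound 1 to compound 3 (beyond the scatter), and a number 14.5 percentage points lower from compound 2 to compound 3 (beyond the scatter). Compound 4 `COc1ccccc1-c1cn2ccnc2c(-c2ccc3ncn(C4CCCCC4)c3c2)n1` carries a different group on the shared core: 2-methoxyphenyl in place of 4-acetylphenyl on an aromatic carbon. Among the measured compounds shown here, no measured step covers this exact swap. The steps of a number 10.5 percentage points lower from compound 1 to compound 2 (beyond the scatter) and a number 25 percentage points lower from compound 1 to compound 3 (beyond the scatter) both show that a substituted phenyl gave less inhibition than the bare phenyl of compound 1, and the step of a number 14.5 percentage points lower from compound 2 to compound 3 (beyond the scatter) shows that the size depends on which group sits there. A 2-methoxyphenyl is expected to fall between those cases, so a rise from compound 3 is expected, though uncertain. Compound 4 is estimated at 15%, from 0% to 32%, meaning a number 12.2 percentage points higher from compound 3 to compound 4 (beyond the scatter).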

Compound 4, a percentage reported as inhibition, at one concentration (the size of the read-out at that concentration, not a potency): 8.07%
The estimate for compound 4 lay 6.9 percentage points above the measured number, and the stated range covers the measured number.
By their numbers in this assay, from the lowest: compounds 3, 4 and 2 (each within the scatter of the next, the first and the last beyond it); then compound 1.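

The step of a number 19.7 percentage points lower from compound 1 to compound 4 (beyond the scatter) makes 2-methoxyphenyl the third substituted phenyl at this position to give a lower number than the bare phenyl in this assay on the shared core. Yet a number 5.3 percentage points higher from compound 3 to compound 4 (within the scatter) and a number 9.2 percentage points lower from compound 2 to compound 4 (within the scatter) leave compound 4 unseparated from either of the other two substituted compounds. Nothing measured here gives a cause for these steps.

Going by these compounds, whether any group on this phenyl can match compound 1 stays open, for instance an amine or a carboxylic acid. Because 2-methoxyphenyl differs from 4-fluorophenyl and 4-acetylphenyl in both the group and its place on the ring, the effects of those two changes also remain unseparated.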